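This account rests on a few compounds, and the source may have more. Where it says the series, first, only, none or still open, it means among the compounds named here.

Measured compounds in an assay on CHO cells for displacement of a labelled ligand from 5-hydroxytryptamine receptor 1D (Homo sapiens); on this read-out higher numbers stand for weaker inhibition and lower numbers for stronger inhibition:

- compound 1 `O=S(=O)(NCC1CCN(CCCc2c[nH]c3ccc(-n4cnnc4)cc23)CC1)c1ccccc1`: 6.2 nM
- compound 2 `C[C@@H](NCC1CCN(CCCc2c[nH]c3ccc(-n4cnnc4)cc23)CC1)c1ccccc1`: 1.4 nM
- compound 3 `C[C@@H](NC1CCN(CCCc2c[nH]c3ccc(-n4cnnc4)cc23)CC1)c1ccccc1`: 0.4 nM

Compound 2 gives 1.4 nM in this assay, which places it between the other two: compound 3 sits below it, with a 3.5-fold lower number from compound 2 to compound 3 (0.54 log units; beyond the scatter), and compound 1 sits above it, with a 4.4-fold lower number from compound 1 to compound 2 (0.65 log units; beyond the scatter). The largest measured step, a 16-fold lower number from compound 1 to compound 3 (1.19 log units; beyond the scatter), joins the two outer compounds.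

Compound 4 `C[C@H](NCC1CCN(CCCc2c[nH]c3ccc(-n4cnnc4)cc23)CC1)c1ccccc1` is the unmeasured compound. Its relation to compound 2: the two compounds have the same atoms and bonds and differ only in configuration as drawn: 1 of 1 stereo elements differ; a stereocentre at a saturated chain carbon is drawn R in compound 2 and S in compound 4.

Within the data shown here, none of the measured steps bears directly on this change. Each of them alters the substituent on the amine nitrogen or the spacing of the amine from the saturated ring, and all of them keep the configuration drawn in compound 2. Among the measured compounds shown here, the series therefore gives no measured precedent for reversing the stereocentre, and the size and direction of the step cannot be read from the data.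

Pending a result, the step from compound 2 is expected to be a 2.5-fold higher number from compound 2 to compound 4 (0.40 log units; beyond the scatter), a weakening within a wide band. Compound 4 is estimated at 3.5 nM, with a range from 0.8 nM to 15 nM.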

Compound 4, half-maximal inhibitory concentration: 4.4 nM
Compound 4: the middle estimate sits 1.3-fold (0.10 log units) below what was measured; measured number inside the range.
By their numbers in this assay, from the lowest: compound 3; then compound 2; then compounds 4 and 1 (each within the scatter of the next).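

In this assay the stereocentre at a saturated chain carbon proves to count, with a 3.1-fold higher number from compound 2 to compound 4 (0.50 log units; beyond the scatter), and that step rests on configuration alone: the fact that compounds 2 and 4 differ only in the configuration as drawn

Drawn S, the 1-phenylethyl group no longer keeps the advantage over phenylsulfonyl that the R form showed, with a 1.4-fold lower number from compound 1 to compound 4 (0.15 log units; within the scatter). The larger 11-fold higher number from compound 3 to compound 4 (1.04 log units; beyond the scatter) combines the reversed stereocentre with ((1-phenylethyl)amino)methyl in place of (1-phenylethyl)amino, so it isolates neither change.

Open, as far as these compounds go, is whether reversing the stereocentre carries the same weight when (1-phenylethyl)amino sits directly on the saturated ring, as in compound 3. Also open, from the compounds shown here alone, is how a benzyl group, which has no stereocentre, or a 1-phenylpropyl group on the amine nitrogen compares with either form of 1-phenylethyl.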